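The source may report more compounds than this note shows. Statements on the series, on what has been measured and on what is new or still open speak of the compounds shown alone.

Measured compounds:
compound 1 `CC(C)CCc1cnc(CCc2ccc(-c3ccccc3C(=O)O)cc2)[nH]1` — in an in vitro functional assay on cells for agonist activity at Bombesin receptor subtype-3 (Mus musculus), read by luminescence and calcium flux (a lower number here means that less compound is needed, a higher number that more compound is needed for the effect), compound 1 gives 10 nM
compound 2 `CC(C)(C)c1cnc(CCc2ccc(-c3ccccc3C(=O)O)cc2)[nH]1` — in this assay compound 2 gives 2750 nM

Going by the values given here, compound 2 stands at the highest number of the two measured compounds, and its only neighbour is compound 1, reached by the step of a 280-fold higher number from compound 1 to compound 2 (2.44 log units; beyond the scatter). That step, the only one measured so far, shows how strongly the group on the aromatic carbon of the five-membered ring sets the outcome.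

Compound 3 `CC(C)(C)CCc1cnc(CCc2ccc(-c3ccccc3C(=O)O)cc2)[nH]1` is built from compound 2 by the change (3,3-dimethylbutyl in place of tert-butyl on an aromatic carbon). The entering group is a chain with two carbons more than the tert-butyl it replaces, so the bulky branched end is no longer attached directly to the ring but carried out on a short chain, much as the isopentyl group of compound 1 is. Because the step of a 280-fold higher number from compound 1 to compound 2 (2.44 log units; beyond the scatter) was large and went toward a higher number when the chain was removed, restoring a chain of this kind is expected to reverse most of that loss, giving a step of a 140-fold lower number from compound 2 to compound 3 (2.14 log units; beyond the scatter). Compound 3 is therefore estimated at 20 nM, with a range from 4 nM to 150 nM.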

Compound 3, half-maximal effective concentration: 6.2 nM
Compound 3: the middle estimate sits 3.2-fold (0.51 log units) above what was measured, and the stated range covers the measured number.
By their numbers in this assay, from the lowest: compounds 3 and 1 (each within the scatter of the next); then compound 2.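

In this assay, 3,3-dimethylbutyl in place of tert-butyl gives a 440-fold lower number from compound 2 to compound 3 (2.65 log units; beyond the scatter), so the bulky branched end does not by itself bring the high number of compound 2: carried on a chain, the same end goes with a low number. The second comparison adds one methyl to the end of the chain, and a 1.6-fold lower number from compound 1 to compound 3 (0.21 log units; within the scatter) shows that isopentyl and 3,3-dimethylbutyl cannot be told apart at this position, which means the extra branching at the far end of the chain leaves the result unchanged within the scatter. Nothing available explains why placing a chain between the branched end and the ring matters so much in this functional read-out.

Going by these compounds, how the number would respond to a short ethyl group, a longer chain such as hexyl, or a chain ending in a cyclohexyl ring remains open, so the chain length needed to keep a low number is still unknown. On these data alone, it is also open whether a hydroxyl group or an amine on the chain would keep the number low.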